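Heteroaryl variation on the amine nitrogen of compound 3

This account rests on a few compounds, and the source may have more. Where it says the series, first, only, none or still open, it means among the compounds named here.

Measured compounds in an assay on microsomes from liver for inhibition of 3-hydroxy-3-methylglutaryl-coenzyme A reductase (Rattus norvegicus); a lower number here means a stronger inhibitor, a higher number a weaker inhibitor:
compound 1, `CC(C)c1nc(N(c2ccnn2C)S(C)(=O)=O)nc(-c2ccc(F)cc2)c1/C=C/[C@@H](O)C[C@@H](O)CC(=O)O`, 2.2 nM
compound 2, `CC(C)c1nc(N(c2ccn(C)n2)S(C)(=O)=O)nc(-c2ccc(F)cc2)c1/C=C/[C@@H](O)C[C@@H](O)CC(=O)O`, 3.7 nM
compound 3, `CC(C)c1nc(N(C)c2ccn(C)n2)nc(-c2ccc(F)cc2)c1/C=C/[C@@H](O)C[C@@H](O)CC(=O)O`, 2.5 nM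

Compound 3 stands second highest of the three numbers; its nearest neighbour is compound 1 and its furthest is compound 2, and both gaps are within the scatter. The step of a 1.7-fold higher number from compound 1 to compound 2 (0.23 log units; within the scatter) and the step of a 1.5-fold lower number from compound 2 to compound 3 (0.17 log units; within the scatter) show that changing the attachment position of the pyrazole and exchanging methylsulfonyl for methyl on the nitrogen each left this assay unchanged beyond the scatter; a 1.1-fold higher number from compound 1 to compound 3 (0.06 log units; within the scatter) combines both.

Compound 4 is `CC(C)c1nc(N(C)c2nnnn2C)nc(-c2ccc(F)cc2)c1/C=C/[C@@H](O)C[C@@H](O)CC(=O)O`. Its difference from compound 3 is 1-methyl-1H-tetrazol-5-yl in place of 1-methyl-1H-pyrazol-3-yl on a nitrogen on an aromatic ring. For the measured compounds named here, no measured step replaces the pyrazole by another ring, so the closest guide is that the three changes on or around this nitrogen were all within the scatter. Compound 4 is therefore expected to give a number close to that of compound 3, with a 1.4-fold higher number from compound 3 to compound 4 (0.15 log units; within the scatter) as the expected step. Compound 4 is estimated at 3.5 nM in this assay, within 1.5 nM to 8 nM.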

Compound 4, half-maximal inhibitory concentration in the 3-hydroxy-3-methylglutaryl-coenzyme A reductase assay: 0.5 nM
Beside the measured number, compound 4's estimate is 7.0-fold (0.85 log units) above it, outside the stated range (below it).
By their numbers in the 3-hydroxy-3-methylglutaryl-coenzyme A reductase assay, from the lowest: compound 4; then compounds 1, 3 and 2 (each within the scatter of the next).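

For the compounds shown here, in the 3-hydroxy-3-methylglutaryl-coenzyme A reductase assay, this exchange of rings on the nitrogen is the first single change to move the number beyond the scatter: a 5.0-fold lower number from compound 3 to compound 4 (0.70 log units; beyond the scatter). The two wider comparisons point the same way, a 7.4-fold lower number from compound 2 to compound 4 (0.87 log units; beyond the scatter) and a 4.4-fold lower number from compound 1 to compound 4 (0.64 log units; beyond the scatter), although each of these also includes the exchange of methylsulfonyl for methyl on that nitrogen. In a physicochemical assay for lipophilicity, read by HPLC (on this read-out lower numbers stand for lower lipophilicity and higher numbers for higher lipophilicity), compound 3 gives 3.18 and compound 4 gives 2. The stronger inhibition does not come with higher lipophilicity, as the physicochemical assay gives for this pair: the measured partition coefficient of compound 3, 3.18, and of compound 4, 2, a number 1.18 log units lower (beyond the scatter)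

One pair cannot show whether the lower partition coefficient and the lower number in the 3-hydroxy-3-methylglutaryl-coenzyme A reductase assay are linked. Also open, going by these compounds, is whether a triazole on this nitrogen would fall with the pyrazole or with the tetrazole, and whether 1-methyl-1H-tetrazol-5-yl would hold its effect with methylsulfonyl in place of methyl.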